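Opening a Ring: From Compound 2 to Compound 4

The source may hold more compounds than are shown below. What is called first, only, known or untested is meant among the compounds shown, and "the series" means these compounds.

Compound 2 `COc1cc(C)c(S(=O)(=O)N(C)CCOCC(=O)N2CCC(CN3CCN(C)CC3)CC2)c(C)c1` was tested in an ADME assay on microsomes from liver (Homo sapiens) for metabolic stability, with a stated time of 30 min, tested at 1 uM (on this read-out higher numbers stand for a more stable compound and lower numbers for a less stable compound), where compound 2 gives 81%. Among the three measured compounds this is the second highest number. Its nearest neighbour is compound 3 `CCN1CCC(N2CCN(C(=O)COCCN(C)S(=O)(=O)c3c(C)cc(OC)cc3C)CC2)CC1`, which in this assay gives 85%, a gap that lies within the scatter. Compound 1 `COc1cc(C)c(S(=O)(=O)N(C)CCOCC(=O)N2CCN([C@@H]3CN4CCC3CC4)CC2)c(C)c1` lies furthest away and in this assay gives 57%, a gap beyond the scatter. Among the measured compounds shown here, the only single-place step among the measured compounds runs a number 28 percentage points higher from compound 1 to compound 3 (beyond the scatter), a change made on an amine nitrogen in a ring.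

Compound 4 `COc1cc(C)c(S(=O)(=O)N(C)CCOCC(=O)N2CCC(C(O)CN(C)C)CC2)c(C)c1` differs from compound 2 on a saturated ring carbon: 2-(dimethylamino)-1-hydroxyethyl in place of (4-methylpiperazin-1-yl)methyl on a saturated ring carbon. For the measured compounds named here, this change is of a different kind from the one measured step, which offers no guide to its size or direction. Going by the values given here, with no step that bears on it, the expectation for compound 4 is a number close to that of compound 2, and the step of a number 9 percentage points lower from compound 2 to compound 4 (within the scatter) is expected to stay within the scatter. Compound 4 is accordingly estimated at 72%, with a range from 50% to 92%.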

Compound 4, percent of the compound remaining: 100%
Compound 4: the middle estimate sits 28 percentage points below what was measured, outside the stated range (above it).
By their numbers in this assay, from the lowest: compound 1; then compounds 2 and 3 (each within the scatter of the next); then compound 4.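

In this assay, the swap of (4-methylpiperazin-1-yl)methyl for 2-(dimethylamino)-1-hydroxyethyl gives a number 19 percentage points higher from compound 2 to compound 4 (beyond the scatter) on a saturated ring carbon, so the number responds to a change at this place, three ring bonds from the ring nitrogen, and not only to the change on an amine nitrogen in a ring seen earlier. The entering group has no ring, fewer heavy atoms and one hydrogen-bond donor, whereas the leaving group has a ring and no donor. No measurement at hand accounts for the step.

From the compounds shown here alone, the ring loss, the hydroxyl and the smaller size all arrive together, so their separate shares remain open. A plain 2-(dimethylamino)ethyl group, the same open chain without the hydroxyl, would begin to separate them.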